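Chalcone-like series: aryl swap on the chain from compound 1

The source may hold more compounds than are shown below. What is called first, only, known or untested is meant among the compounds shown, and "the series" means these compounds.

Compound 1 `Cc1ccc(CS/C(=C/c2c(O)cc(O)cc2O)C(=O)c2ccc(Cl)cc2)cc1` is the reference point. Among the compounds with values here, in a functional assay on DU-145 cells (Homo sapiens) for inhibition, read by trypan blue exclusion, with a stated time of 96 h (on this read-out higher numbers stand for weaker inhibition of growth and lower numbers for stronger inhibition of growth), compound 1 gives 50000 nM, the only plain number so far. Compound 2 `O=C(/C(=C\c1c(O)cc(O)cc1O)S(=O)(=O)c1ccc(Br)cc1)c1ccc(Cl)cc1` differs from it in the group on the double-bonded chain carbon bound to a carbonyl carbon and a double-bonded chain carbon. In this assay compound 2 reaches only a limit, > 100000 nM, which is a boundary of the assay and not a number. That is reflected in the limit of > 100000 nM in this assay, at which 1 of the 2 values shown sits, and yields an at least 2.0-fold higher number from compound 1 to compound 2 (0.30 log units; that floor lies within the scatter).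

Compound 3 `Cc1ccc(CS/C(=C/c2ccc(Cl)cc2)C(=O)c2ccc(Cl)cc2)cc1` is not yet measured. It differs from compound 1 by 4-chlorophenyl in place of 2,4,6-trihydroxyphenyl on a double-bonded chain carbon bound to a double-bonded chain carbon. Within the data shown here, no measured step touches that position: the single measured step concerns the sulfanyl side of the chain, so it does not bear on this change, and its size cannot be carried over.

With nothing measured for this change, compound 3 is expected to sit near compound 1 or weaker, with the estimate for compound 3 in this assay put at 80000 nM, expected between 20000 nM and 300000 nM. That estimate amounts to a 1.6-fold higher number from compound 1 to compound 3 (0.20 log units; within the scatter).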

Compound 3, concentration for 50% growth inhibition: 10000 nM
The estimate for compound 3 lay 8.0-fold (0.90 log units) above the measured number; measured number outside the range, below it.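

Within the data shown here, the aryl group on the double-bonded chain carbon bound to a double-bonded chain carbon is the first place where a change moves the read-out beyond the scatter: in this assay, 4-chlorophenyl in place of 2,4,6-trihydroxyphenyl gives a 5.0-fold lower number from compound 1 to compound 3 (0.70 log units; beyond the scatter). The 2,4,6-trihydroxyphenyl group is therefore not required for growth inhibition on this read-out, and on the core of compound 1 the 4-chlorophenyl group is the better of the two. Nothing measured here gives a reason for this step.

The swap removes the hydroxyl groups and brings in chlorine in one move, so the compounds shown do not separate these two parts of the change, and a plain phenyl or a 4-aminophenyl group at this place would be needed to tell them apart. On these data alone, it also remains open whether the 4-chlorophenyl group gives a step of similar size when the (4-methylbenzyl)sulfanyl group is replaced by the (4-bromophenyl)sulfonyl group of compound 2.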